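Anilinoquinazoline thioureas: swapping the aniline substituent

The source may report more compounds than this note shows. Statements on the series, on what has been measured and on what is new or still open speak of the compounds shown alone.

Measured so far:
compound 1 `NS(=O)(=O)c1ccc(NC(=S)Nc2ccc3ncnc(Nc4ccc(F)c(Cl)c4)c3c2)cc1`, 37600 nM
compound 2 `C#Cc1cccc(Nc2ncnc3ccc(NC(=S)Nc4ccc(S(N)(=O)=O)cc4)cc23)c1`, 15300 nM

Both compounds share the same core and sulfonamide-bearing thiourea and differ only in the aniline on the core. In a functional assay on A-431 cells (Homo sapiens) for antiproliferative activity, read by MTT assay, with a stated time of 72 h (a higher number here means a weaker inhibitor, a lower number a stronger inhibitor), compound 2 gives 15300 nM and so stands at the lower of the two numbers; compound 1 gives 37600 nM, and the move a 2.5-fold lower number from compound 1 to compound 2 (0.39 log units; beyond the scatter) is a modest change from one aniline to another.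

Compound 3 `NS(=O)(=O)c1ccc(NC(=S)Nc2ccc3ncnc(Nc4cccc(C(F)(F)F)c4)c3c2)cc1` keeps the aniline pattern of compound 2 but carries trifluoromethyl in place of ethynyl on an aromatic carbon. Among the measured compounds shown here, the only measured step that bears on this position is the one from compound 1 to compound 2, a modest change for a substituent swap on the same ring; no step compares two groups at the single place where compound 2 and compound 3 differ. A step of similar or smaller size, in either direction, is therefore the reasonable expectation, with no strong case for a change beyond the scatter.

Compound 3 is expected to give about 20000 nM in this assay, in the range 8000 nM to 50000 nM, a step of a 1.3-fold higher number from compound 2 to compound 3 (0.12 log units; within the scatter).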

Compound 3, half-maximal inhibitory concentration: 21700 nM
Compound 3: middle estimate off by 1.1-fold (0.04 log units), on the low side; the range from low to high includes it.
By their numbers in this assay, from the lowest: compounds 2, 3 and 1 (each within the scatter of the next, the first and the last beyond it).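

In this assay the change of trifluoromethyl in place of ethynyl on an aromatic carbon gives a 1.4-fold higher number from compound 2 to compound 3 (0.15 log units; within the scatter) and so, unlike the earlier pair, tests two groups at this single place on the same ring, which this assay does not tell apart. Among the compounds shown here, the change of 3-(trifluoromethyl)phenyl in place of 3-chloro-4-fluorophenyl gives a 1.7-fold lower number from compound 1 to compound 3 (0.24 log units; within the scatter) and leaves a 2.5-fold lower number from compound 1 to compound 2 (0.39 log units; beyond the scatter) as the only step among the three anilines that lies beyond the scatter. No measurement available here gives a reason for any of these steps.

The compounds shown leave open whether an amine or a carboxylic acid on this aromatic carbon, or a longer chain in place of ethynyl, would produce a step beyond the scatter from the numbers seen so far. For the compounds shown here, they also leave open how far the sulfonamide-bearing thiourea contributes to the numbers in this assay, since it stays the same in all three compounds and no compound here carries a urea or an amide in its place.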